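Combining Chloro and Fluoro on the Benzyl Ether Ring

This account rests on a few compounds, and the source may have more. Where it says the series, first, only, none or still open, it means among the compounds named here.

Measured compounds:
Compound 1, `O=C(Nc1cccnc1)c1ccccc1OCc1ccccc1F`: 3500 nM
Compound 2, `Cc1ccccc1COc1ccccc1C(=O)Nc1cccnc1`: 1500 nM
Compound 3, `O=C(Nc1cccnc1)c1ccccc1OCc1cccc(Cl)c1`: 1400 nM

All three were tested in an assay on lysate for inhibition of phosphatidylcholine:ceramide cholinephosphotransferase 2 (Homo sapiens), read by HPLC, with stated times of 30 min and 2 h; on this read-out higher numbers stand for weaker inhibition and lower numbers for stronger inhibition. Compound 2 stands second highest of the three numbers; its nearest neighbour is compound 3, a step within the scatter (a 1.1-fold lower number from compound 2 to compound 3 (0.03 log units; within the scatter)), and its furthest is compound 1, which gives the highest number.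

Compound 4, `O=C(Nc1cccnc1)c1ccccc1OCc1cccc(Cl)c1F`, has not been measured. It differs from compound 2 in one place: 3-chloro-2-fluorophenyl in place of 2-methylphenyl on a saturated chain carbon bound to an oxygen on an aromatic ring

Among the measured compounds shown here, two measured steps bear on this change. The first, a 2.3-fold lower number from compound 1 to compound 2 (0.37 log units; beyond the scatter), shows that methyl in place of fluoro on the aromatic carbon lowered the number modestly, so going back toward fluoro should raise it. The second, a 1.1-fold lower number from compound 2 to compound 3 (0.03 log units; within the scatter), shows that 3-chlorophenyl in place of 2-methylphenyl made no difference beyond the scatter. A related step, a 2.5-fold lower number from compound 1 to compound 3 (0.40 log units; beyond the scatter), points the same way as the first. Compound 4 carries both the fluoro and the chloro, so the number is expected to rise, with the step of a 1.7-fold higher number from compound 2 to compound 4 (0.22 log units; within the scatter) estimated to be modest.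

Compound 4 is therefore estimated at 2500 nM in this assay, within a range from 1000 nM to 6000 nM.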

Compound 4, half-maximal inhibitory concentration: 3100 nM
Estimate against measurement, compound 4: 1.2-fold (0.09 log units) below; the range from low to high includes it.
By their numbers in this assay, from the lowest: compounds 3 and 2 (each within the scatter of the next); then compounds 4 and 1 (each within the scatter of the next).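

Among the compounds shown here, compound 4 gives the first reading of fluoro on its own, and fluoro in place of hydrogen on the aromatic carbon weakens inhibition modestly (a 2.2-fold higher number from compound 3 to compound 4 (0.35 log units; beyond the scatter)). Chloro in place of hydrogen on the same fluorinated ring does not separate the two compounds (a 1.1-fold lower number from compound 1 to compound 4 (0.05 log units; within the scatter)), so with fluoro present, chloro brings none of the benefit that the earlier step to the 3-chlorophenyl compound seemed to promise, and the two groups do not act independently of each other. The 3-chloro-2-fluorophenyl group also falls short of the 2-methylphenyl group (a 2.1-fold higher number from compound 2 to compound 4 (0.32 log units; beyond the scatter)), and among these four compounds the two that carry fluoro, compound 1 and compound 4, give the higher numbers, with no compound here going against that split.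

No measurement here explains why fluoro has this effect. On these data alone, it also stays open whether a 3-chloro-2-methylphenyl group, or a ring bearing a methoxy group, would hold the lower numbers seen for compound 2 and compound 3 or rise as the fluoro compounds do.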